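Biguanide series: heptyl to cyclopentyl on the amine nitrogen

This account rests on a few compounds, and the source may have more. Where it says the series, first, only, none or still open, it means among the compounds named here.

Measured compounds:
compound 1, `CCCCCCCNC(=N)NC(=N)Nc1ccc(F)c(F)c1`, 4300 nM
compound 2, `CCN(CC)C(=N)NC(=N)Nc1ccc(C(F)(F)F)cc1`, 6200 nM
compound 3, `N=C(NC(=N)NC1CCCC1)Nc1ccc(F)cc1F`, 37800 nM

Three compounds of the shared core have a number in a functional assay on T-24 cells (Homo sapiens) for antiproliferative activity, read by MTT assay, with a stated time of 72 h; on this read-out lower numbers stand for stronger inhibition and higher numbers for weaker inhibition. In this assay compound 1 gives 4300 nM, the lowest of the three. Compound 2 gives 6200 nM, which sits within the scatter of compound 1, so no order between those two can be read. Compound 3 gives 37800 nM, a gap from compound 1 that lies beyond the scatter; compound 3 carries a cyclopentyl on the amine nitrogen and a differently fluorinated phenyl, so the two changes cannot be separated on these numbers.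

Compound 4, `N=C(NC(=N)NC1CCCC1)Nc1ccc(F)c(F)c1`, is not yet measured. It differs from compound 1 in one place: cyclopentyl in place of heptyl on an amine nitrogen. The aromatic part of compound 1 is kept. Going by the values given here, no measured pair isolates this change, so the expectation rests on the weak number of compound 3, the only other cyclopentyl compound, at 37800 nM.

The step from compound 1 to compound 4 in this assay is expected to be a 3.5-fold higher number from compound 1 to compound 4 (0.54 log units; beyond the scatter), towards a higher number, beyond the scatter but not as far as compound 3. Compound 4 is estimated at 15000 nM, with a range from 5000 nM to 45000 nM.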

Compound 4, half-maximal inhibitory concentration: 24900 nM
Compound 4: the middle estimate sits 1.7-fold (0.22 log units) below what was measured; low and high end bracket the measured number.
By their numbers in this assay, from the lowest: compounds 1 and 2 (each within the scatter of the next); then compounds 4 and 3 (each within the scatter of the next).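

In this assay, with the aromatic part of compound 1 held fixed, cyclopentyl in place of heptyl on the amine nitrogen gives a 5.8-fold higher number from compound 1 to compound 4 (0.76 log units; beyond the scatter) as a step beyond the scatter, towards weaker inhibition. The earlier gap to compound 3 mixed two changes, whereas this pair shows that the change on the amine nitrogen alone is enough to move the number beyond the scatter. The two cyclopentyl compounds, compound 4 at 24900 nM and compound 3 at 37800 nM, lie within the scatter of each other, so the different fluorination of the phenyl gives no readable order in this pair, and nothing at hand offers an explanation for the step from heptyl to cyclopentyl.

Still open, as far as these compounds go, is whether the step follows the ring or the chain length, since heptyl and cyclopentyl differ in both, and a straight pentyl chain or a cyclohexyl on the same amine nitrogen would help to part the two. Also open, from the compounds shown here alone, is how an octyl chain, or a heptyl chain carrying an amine, would read on the core of compound 1 in this assay for this series.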